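Ethylcarbamoyl to isopropylcarbamoyl, starting from a limit

The compounds below may be only part of what the source reports. "The series", "measured", "known", "first", "only" and "open" are said of these compounds alone.

Compound 2 `CCCCc1cc2c(=O)c(C(=O)NCC)c[nH]c2cc1OCCOc1ccccc1` gives > 20000 nM in an ADME assay on J774 cells (Mus musculus) for cytotoxicity (on this read-out higher numbers stand for an effect only at larger amounts of compound and lower numbers for an effect already at smaller amounts), and this is a limit of the assay and not a number. Compound 1 `CCCCc1cc2c(=O)c(CC)c[nH]c2cc1OCCOc1ccccc1` carries ethyl where compound 2 carries ethylcarbamoyl. In this assay compound 1 gives 360 nM. Compound 3 `CCCCc1cc2c(=O)c(C(=O)NC(C)C)c[nH]c2cc1OCCOc1ccccc1` differs from compound 2 by methyl in place of hydrogen on a saturated chain carbon bound to an amide-type nitrogen and a saturated chain carbon, which turns ethylcarbamoyl into isopropylcarbamoyl. Among the measured compounds shown here, the one measured step that bears on this change, an at least 55-fold higher number from compound 1 to compound 2 (1.74 log units; beyond the scatter), is large and beyond the scatter, but it replaces ethyl with ethylcarbamoyl and does not alter the chain itself. Compound 3 keeps the amide-type nitrogen on that carbon, so no step beyond the scatter is expected in this assay, and a reading at the same limit is likely. The expected change is a number no higher from compound 2 to compound 3 (the limit leaves the size open). For compound 3 the estimate is 20000 nM, with an expected range of 8000 nM to 40000 nM.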

Compound 3, half-maximal effective concentration: > 20000 nM
Compound 3: only a limit was reported; the forecaster's own chance of this, stated with the estimate: 70%; the middle value sits exactly at the limit.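

In this assay compound 3 gives > 20000 nM, which is a limit of the assay and not a number. The step from ethylcarbamoyl to isopropylcarbamoyl cannot be read, because compound 2 and compound 3 stop at the same reading: the limit of > 20000 nM in this assay, at which 2 of the 3 values shown sit. What the result adds is that putting isopropylcarbamoyl in place of ethyl on the aromatic carbon gives an at least 55-fold higher number from compound 1 to compound 3 (1.74 log units; beyond the scatter), so the large step first seen with ethylcarbamoyl holds for both carbamoyl groups shown.

On these data alone, how far compound 2 and compound 3 lie beyond the limit, and so whether methyl in place of hydrogen changes anything on this chain carbon, stays open. Also open, as far as these compounds go, is whether a longer chain on the amide nitrogen, or a carboxylic acid in place of the carbamoyl group, would bring the reading back within the range of the assay.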